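Fluoro for hydrogen on the bromophenyl ring

The source may report more compounds than this note shows. Statements on the series, on what has been measured and on what is new or still open speak of the compounds shown alone.

Measured so far:
compound 1 `O=C(Nc1ccc(Oc2ccnc3[nH]ccc23)c(F)c1)c1cc2cccnc2n(-c2ccc(Br)cc2F)c1=O` gives "not determined" (no result reported) in a functional assay on NCI-H460 cells (Homo sapiens) for antiproliferative activity, read by MTT assay, with a stated time of 72 h; a higher number here means a weaker inhibitor, a lower number a stronger inhibitor
compound 2 `Cn1ccc2c(Oc3ccc(NC(=O)c4cc5cccnc5n(-c5ccc(Br)cc5)c4=O)cc3F)ccnc21` gives 420 nM in this assay

Within the data shown here, compound 2 stands as the only entry with a number in this assay; compound 1 carries no result there, so nothing can be said about how the two compare. The next step goes from compound 2 to compound 3 `Cn1ccc2c(Oc3ccc(NC(=O)c4cc5cccnc5n(-c5ccc(Br)cc5F)c4=O)cc3F)ccnc21`. The change is fluoro in place of hydrogen on an aromatic carbon, in words: fluoro in place of hydrogen on an aromatic carbon, ortho to a large group and meta to the bromo group, so that 4-bromophenyl becomes 4-bromo-2-fluorophenyl. Among the measured compounds shown here, no step between two measured compounds exists to calibrate this change. An exchange of a single hydrogen for fluoro on this ring is expected to move this assay little, either way, most likely within the usual scatter. Compound 3 is therefore estimated at 350 nM, with a range of 150 nM to 900 nM. The expected step from compound 2 to compound 3 is a 1.2-fold lower number from compound 2 to compound 3 (0.08 log units; within the scatter).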

Compound 3, half-maximal inhibitory concentration: 3150 nM
Estimate against measurement, compound 3: 9.0-fold (0.95 log units) below; the measured number lies above the stated range.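

In this assay, among these compounds, the exchange of hydrogen for fluoro, ortho to a large group and meta to the bromo group, gives a 7.5-fold higher number from compound 2 to compound 3 (0.88 log units; beyond the scatter), the first calibrated step at this position. A single added heavy atom, with no ring, no hydrogen-bond donor or acceptor and no net charge, is therefore enough to change the read-out clearly, so this carbon of the 4-bromophenyl ring cannot be treated as a place where a small exchange passes unnoticed, and compound 2 at 420 nM is the stronger of the pair. Nothing measured on these compounds accounts for the loss.

The step between compound 1 and compound 3, which differ in the methyl group on the shared core, cannot be read, as compound 1 carries no number. Also open, from the compounds shown here alone, is whether the step belongs to fluoro alone or would recur with chloro, a methoxy group or an amine on the same carbon, and whether fluoro on another carbon of this ring would give a step of similar size.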